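The source may report more compounds than this note shows. Statements on the series, on what has been measured and on what is new or still open speak of the compounds shown alone.

Measured so far, in a functional assay on HT-29 cells (Homo sapiens) for inhibition; a higher number here means a weaker inhibitor, a lower number a stronger inhibitor:
- Compound 1, `O=S(=O)(c1ccccc1)n1ccc2cc(/C=C\c3ccc4ccccc4c3)ccc21`: compound 1 gives > 5000 nM, which is a limit of the assay and not a number.
- Compound 2, `C(=C\c1ccc2[nH]ccc2c1)\c1ccc2ccccc2c1`: compound 2 gives > 5000 nM, again a limit rather than a number.
- Compound 3, `COc1cc(/C=C/c2ccc3c(ccn3S(=O)(=O)c3ccccc3)c2)cc(OC)c1OC`: compound 3 gives > 5000 nM, also a limit.

Compound 1 and compound 2 share a core and differ in one place, namely (hydrogen in place of phenylsulfonyl on an aromatic nitrogen). Because both values sit at the limit of > 5000 nM in this assay, at which 3 of the 3 values shown sit, the step that the two limits leave unreadable from compound 1 to compound 2 cannot be read in size or direction; the two limits leave it open.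

Compound 3 carries a different core from compound 1, and the difference between the two cores is not broken down here. Compound 4, `COc1cc(/C=C/c2ccc3[nH]ccc3c2)cc(OC)c1OC`, is not yet measured. It stands to compound 3 exactly as compound 2 stands to compound 1: the change is hydrogen in place of phenylsulfonyl on an aromatic nitrogen, on the same kind of place, an aromatic nitrogen of a five-membered aromatic ring with 1 nitrogen within a fused system of two rings. The earlier instance of this change gave no readable step. With all three measured values resting at the same limit, the expectation for compound 4 is that the step that the limit leaves unreadable from compound 3 to compound 4 is small, and the estimate for compound 4 in this assay is 12000 nM, expected to lie between 3000 nM and 60000 nM.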

Compound 4, half-maximal inhibitory concentration: 280 nM
Estimate against measurement, compound 4: 43-fold (1.63 log units) above; the measured number lies below the stated range.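

In this assay, among these compounds, putting hydrogen in place of phenylsulfonyl on the aromatic nitrogen gives an at least 17-fold lower number from compound 3 to compound 4 (1.25 log units; beyond the scatter), the one instance where the change has a readable effect, and that effect is large. Compound 2 also carries hydrogen on that nitrogen and gives > 5000 nM, which is a limit of the assay and not a number. The same change from compound 1 to compound 2 cannot be read in size or direction, so the series neither shows that the large step carries over from one core to the other nor shows that it fails to, because the values for that pair rest on a single limit: the limit of > 5000 nM in this assay, at which 3 of the 4 values shown sit.

Among the compounds shown, only hydrogen and phenylsulfonyl can be set against each other on this nitrogen, so it remains open how a small group such as methyl or acetyl would fare there on the core of compound 3. On these data alone, it also remains open whether the step would hold on a core bearing a different group, such as an amine or a carboxylic acid, in place of the methoxy groups of compound 4.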